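Amide replacements on the shared core: compound 4

This account rests on a few compounds, and the source may have more. Where it says the series, first, only, none or still open, it means among the compounds named here.

Measured compounds in an assay on cells for agonist activity at vitamin D3 receptor (Homo sapiens), with a stated time of 96 h; a lower number here means that less compound is needed, a higher number that more compound is needed for the effect:
compound 1 `CCn1c(C(=O)NCCN(C)C)ccc1C(CC)(CC)c1ccc(OCCC(O)(CC)CC)c(C)c1`: 82 nM
compound 2 `CCN(CC)CCNC(=O)c1ccc(C(CC)(CC)c2ccc(OCCC(O)(CC)CC)c(C)c2)n1CC`: 2.3 nM
compound 3 `C#CC(C)OC(=O)c1ccc(C(CC)(CC)c2ccc(OCCC(O)(CC)CC)c(C)c2)n1CC`: 2650 nM

Compound 3 stands at the highest number of the three. Its nearest neighbour is compound 1 (a 32-fold higher number from compound 1 to compound 3 (1.51 log units; beyond the scatter)), and compound 2 lies furthest from it (a 1200-fold higher number from compound 2 to compound 3 (3.06 log units; beyond the scatter)). Between compound 1 and compound 2 the change is a 36-fold lower number from compound 1 to compound 2 (1.55 log units; beyond the scatter).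

Compound 4 `CCn1c(C(=O)Nc2ccc(OC(F)(F)F)cc2)ccc1C(CC)(CC)c1ccc(OCCC(O)(CC)CC)c(C)c1` is not yet measured. It differs from compound 3 in one place: (4-(trifluoromethoxy)phenyl)amino in place of (1-methylprop-2-yn-1-yl)oxy on a carbonyl carbon. Both steps that end at compound 3 bear on this change, since each of them removes an amide-type nitrogen from the carbonyl carbon and puts an ester oxygen there. Among the measured compounds shown here, compound 4 restores a nitrogen on that carbonyl carbon, but the group it carries, a (4-(trifluoromethoxy)phenyl)amino, has no counterpart among the measured compounds, so the size of the return is open. A step back towards the numbers of compound 1 and compound 2 is expected, but not the whole distance; the expected step is an 18-fold lower number from compound 3 to compound 4 (1.25 log units; beyond the scatter).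

For compound 4 the estimate in this assay is 150 nM, with a range from 15 nM to 1500 nM.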

Compound 4, half-maximal effective concentration: > 10000 nM
Compound 4: no number, only a limit; the forecaster's own chance of this, stated with the estimate: 5%; middle value at least 66-fold (1.82 log units) from the limit.
By their numbers in this assay, from the lowest: compound 2; then compound 1; then compound 3. At a limit, above all of these: compound 4.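

The reading for compound 4 in this assay is a limit and not a number: the limit of > 10000 nM in this assay, at which 1 of the 4 values shown sits.

An amide-type nitrogen on the carbonyl carbon therefore does not by itself bring the low numbers of the two measured amides, since 4-(trifluoromethoxy)phenyl on that nitrogen gives an at least 4300-fold higher number from compound 2 to compound 4 (3.63 log units; beyond the scatter) and an at least 120-fold higher number from compound 1 to compound 4 (2.08 log units; beyond the scatter). Nor does this amide return towards them from the ester, the step being an at least 3.7-fold higher number from compound 3 to compound 4 (0.57 log units; beyond the scatter), so among these compounds the order follows the group carried on the carbonyl carbon and not the presence of the nitrogen; compound 4 goes against any reading of amides as lower than the ester.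

On these data alone, how far the number of compound 4 lies past its limit stays open, and so does the size of the step from the ester. The change from either amine-bearing amide also swaps an aminoethyl chain for an aromatic ring in one move, so a 2-phenylethyl group or an unsubstituted phenyl on the amide-type nitrogen would be needed to tell the loss of the amine from the entry of the ring and its trifluoromethoxy group.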